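The source may hold more compounds than are shown below. What is called first, only, known or untested is meant among the compounds shown, and "the series" means these compounds.

Measured so far:
- compound 1 `CC(C)c1cc(C(C)C)c(S(=O)(=O)Nc2cccc3cccnc23)c(C(C)C)c1`: "not determined" (no result reported)
- compound 2 `O=S(=O)(Nc1cccc2cccnc12)c1ccc(F)cc1`: "not determined" (no result reported)
- compound 3 `O=S(=O)(Nc1cccc2cccnc12)c1cnc(Cl)c(Br)c1`: 67400 nM

The three compounds share a core and differ in the aromatic group on the sulfonyl side. In an ADME assay on Vero cells (Homo sapiens) for cytotoxicity against Vero (Chlorocebus sabaeus), read by MTT assay (on this read-out lower numbers stand for higher toxicity in this test and higher numbers for lower toxicity in this test), compound 2 stands at "not determined" (no result reported), so it offers no number to start from. Compound 1 is in the same position at "not determined" (no result reported). Among the compounds with values here, only compound 3 carries a number, at 67400 nM, and no step between measured compounds exists to show how far a single change moves this read-out.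

Compound 4 `O=S(=O)(Nc1cccc2cccnc12)c1ccc(-c2ccccc2)cc1` is the next to be read. The change is phenyl in place of fluoro on an aromatic carbon, para to a large group.

With no value for compound 2, the size of this step cannot be measured from the series. Within the data shown here, a modest move toward lower numbers is expected, though nothing measured so far demonstrates it, and a step no larger than the scatter would not be surprising. Among the measured compounds shown here, the single anchor is compound 3 at 67400 nM, which sets the level of the estimate, and the range is kept wide for that reason.

In this assay, the expected value for compound 4 is 40000 nM, with an estimated range from 12000 nM to 130000 nM.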

Compound 4, half-maximal cytotoxic concentration: 245000 nM
For compound 4 the middle estimate is 6.1-fold (0.79 log units) below the measured one; measured number above the stated range.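

Within the data shown here, with compound 2 at "not determined" (no result reported) and compound 4 at 245000 nM in this assay, no step between these two compounds can be read. The compounds shown leave open how far phenyl in place of fluoro moves this read-out. Nothing available bears on an explanation of the result.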